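Trimming Benzyl to Methyl on Two Related Cores

A few compounds are considered here, and "the series" means these few. Any claim that something is new, unique, unknown or untested is made for them only; others in the source may bear on it.

Compound 1 `Cc1[nH]n(-c2nc3c(C)cccc3[nH]2)c(=O)c1Cc1ccccc1` is the point of departure. In an assay on isolated protein for inhibition of alpha-ketoglutarate-dependent dioxygenase alkB homolog 3 (Homo sapiens), read by polymerase chain reaction, with a stated time of 1 h (a higher number here means a weaker inhibitor, a lower number a stronger inhibitor), compound 1 gives 5900 nM. Compound 3 `Cc1[nH]n(-c2nc3c(C)cccc3[nH]2)c(=O)c1C` differs from compound 1 by the change (hydrogen in place of phenyl on a saturated chain carbon bound to an aromatic carbon). Compound 3 gives in this assay only a limit of the assay, > 10000 nM. The step of an at least 1.6-fold higher number from compound 1 to compound 3 (0.22 log units; that floor lies within the scatter) is therefore only a floor, and it is a floor because of the limit of > 10000 nM in this assay, at which 2 of the 3 values shown sit. Compound 2 `O=c1c(Cc2ccccc2)c(-c2ccccc2)[nH]n1-c1nc2ccccc2[nH]1` carries a different core; how its core differs from that of compound 1 is not broken down here. In this assay compound 2 likewise reaches only a limit of the assay, > 10000 nM. Compound 4 `Cc1c(-c2ccccc2)[nH]n(-c2nc3ccccc3[nH]2)c1=O` stands to compound 2 as compound 3 stands to compound 1: the same change, (hydrogen in place of phenyl on a saturated chain carbon bound to an aromatic carbon). Compound 2 already sits at the limit, and on the core of compound 1 this change gave no stronger inhibitor. Resting on the step of an at least 1.6-fold higher number from compound 1 to compound 3 (0.22 log units; that floor lies within the scatter), the expected size here is a step that the limit leaves unreadable from compound 2 to compound 4, with the result most likely again a limit. For compound 4 in this assay the estimate is 20000 nM, expected to lie between 8000 nM and 60000 nM.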

Compound 4, half-maximal inhibitory concentration: > 10000 nM
Compound 4 gave a limit, no number; the forecaster's own chance of this, stated with the estimate: 85%; the middle value does not contradict the limit.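

Compound 2 and compound 4 both reach only a limit in this assay, so no step between them can be read: the limit of > 10000 nM in this assay, at which 3 of the 4 values shown sit.

The compounds shown leave open what size the change from benzyl to methyl has on the core of compound 2, and how compound 2, compound 3 and compound 4 rank among themselves.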